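Swapping the carbonyl substituent from compound 1 to compound 3

The source may hold more compounds than are shown below. What is called first, only, known or untested is meant among the compounds shown, and "the series" means these compounds.

Measured so far in a functional assay on HT-29 cells (Homo sapiens) for inhibition, read by CellTiter-Glo, with a stated time of 72 h; a lower number here means that less compound is tolerated, a higher number that more compound is tolerated
- compound 1 (`CC1=C(CC(=O)N2CCN(CCCN(C)C)CC2)c2cc(F)ccc2/C1=C\c1ccc([S+](C)[O-])cc1`) gives 23800 nM
- compound 2 (`CC1=C(CC(=O)N2CCN(CCCN(C)C)CC2)c2cc(F)ccc2/C1=C\c1nc2ccccc2s1`) gives 1620 nM

Compound 1 stands highest of the two numbers. Within the data shown here, its only measured step is large: a 15-fold lower number from compound 1 to compound 2 (1.17 log units; beyond the scatter) (compound 2 is therefore its nearest neighbour). Compound 3 (`CC1=C(CC(=O)N(C)CCN(C)S(C)(=O)=O)c2cc(F)ccc2/C1=C\c1ccc([S+](C)[O-])cc1`) keeps the core of compound 1 and differs on a carbonyl carbon (methyl(2-(methyl(methylsulfonyl)amino)ethyl)amino in place of 4-(3-(dimethylamino)propyl)piperazin-1-yl on a carbonyl carbon), with methyl(2-(methyl(methylsulfonyl)amino)ethyl)amino in place of 4-(3-(dimethylamino)propyl)piperazin-1-yl. The measured step changes another place, the group on the double-bonded chain carbon, and leaves the carbonyl substituent untouched. Among the measured compounds shown here, it bears only indirectly, showing that numbers in this small set can move far, and no measured step covers the present change. Compound 3 keeps the chain-carbon group of compound 1 (23800 nM), so a number of similar size or somewhat higher is expected in this assay. The expected change, with wide uncertainty, is (a 1.6-fold higher number from compound 1 to compound 3 (0.20 log units; within the scatter)). For compound 3 the estimated value is 38000 nM (expected range 14000 nM to 100000 nM).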

Compound 3, half-maximal cytotoxic concentration: 12400 nM
For compound 3 the middle estimate is 3.1-fold (0.49 log units) above the measured one; measured number below the stated range.
By their numbers in this assay, from the lowest: compound 2; then compounds 3 and 1 (each within the scatter of the next).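

In this assay, among these compounds, this is the first reading at the carbonyl carbon: with the shared core held, methyl(2-(methyl(methylsulfonyl)amino)ethyl)amino in place of 4-(3-(dimethylamino)propyl)piperazin-1-yl gives a 1.9-fold lower number from compound 1 to compound 3 (0.28 log units; within the scatter). The exchange stays within the scatter even though the entering group has no ring, whereas the leaving group carries a six-membered non-aromatic ring, so this one pair gives no sign that the ring or the dimethylamino end of the leaving group is needed for the number seen. The step at the double-bonded chain carbon, a 15-fold lower number from compound 1 to compound 2 (1.17 log units; beyond the scatter), remains the only one beyond the scatter, and no measurement on hand offers a reason for the difference between the two places.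

From the compounds shown here alone, whether methyl(2-(methyl(methylsulfonyl)amino)ethyl)amino leaves the number equally unchanged when paired with the chain-carbon group of compound 2 stays open. Also open, going by these compounds, is how far this tolerance extends, for instance to a hydroxyl on the carbonyl carbon, which would give a carboxylic acid, or to a longer chain between the two nitrogens of the entering group.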